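Formyl in place of hydroxymethyl on compound 1

The compounds below may be only part of what the source reports. "The series", "measured", "known", "first", "only" and "open" are said of these compounds alone.

Compound 1 `OCc1ccccc1/C=C/Cc1cc2c(cc1O)CCO2` is the stronger of the two measured compounds: in a functional assay for inhibition, with Homo sapiens as the target (a lower number here means a stronger inhibitor, a higher number a weaker inhibitor), compound 1 gives 130 nM, while compound 2 `CC(=O)c1ccc(NCc2c(O)ccc3c2CCCO3)cc1` gives 11000 nM, a gap well beyond the usual scatter. Compound 3 `O=Cc1ccccc1/C=C/Cc1cc2c(cc1O)CCO2` differs from compound 1 by formyl in place of hydroxymethyl on an aromatic carbon. Going by the values given here, no step between measured compounds covers this change, so the expectation rests on compound 1 alone. Only a small step is expected, a 1.9-fold higher number from compound 1 to compound 3 (0.28 log units; within the scatter), leaning toward a weaker inhibitor but probably inside the scatter. Compound 3 is estimated at 250 nM, with a range from 80 nM to 800 nM.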

Compound 3, half-maximal inhibitory concentration: 70 nM
Beside the measured number, compound 3's estimate is 3.6-fold (0.55 log units) above it; the whole stated range lies above it.
By their numbers in this assay, from the lowest: compounds 3 and 1 (each within the scatter of the next); then compound 2.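

In this assay, formyl in place of hydroxymethyl on this aromatic carbon gives a 1.9-fold lower number from compound 1 to compound 3 (0.27 log units; within the scatter), so the two groups cannot be told apart here. In this pair, a hydrogen-bond donor on the group at this place is not needed to keep the number in the same range. No measurement on hand accounts for this result.

From the compounds shown here alone, whether an aminomethyl group or a carboxylic acid at this aromatic carbon would stay in that range remains open. So does the outcome with a longer chain bearing a terminal hydroxyl.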